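Notes on replacing phenyl with 5-ethylpyridin-3-yl

The compounds below may be only part of what the source reports. "The series", "measured", "known", "first", "only" and "open" are said of these compounds alone.

Measured so far in an ADME assay on HEK293 cells (Homo sapiens) for cytotoxicity, read by resazurin assay, with a stated time of 72 h; a lower number here means that less compound is tolerated, a higher number that more compound is tolerated:
- compound 1 `COc1cccc(CNC(=O)c2nc3ccc(F)c(OCCc4ccc(N)cc4)c3c(=O)[nH]2)c1`: > 20000 nM (a limit, not a number)
- compound 2 `O=C(O)c1ccc(COCc2cccc3nc(C(=O)NCc4ccccc4)[nH]c(=O)c23)cc1`: > 20000 nM (a limit, not a number)

Compound 2 stands at > 20000 nM in this assay, which is a limit of the assay and not a number. The picture so far is the limit of > 20000 nM in this assay, at which 2 of the 2 values shown sit. For the measured compounds named here, neither compound therefore gives a number to work from, and no measured step connects them.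

The next compound is compound 3 `CCc1cncc(CNC(=O)c2nc3cccc(COCc4ccc(C(=O)O)cc4)c3c(=O)[nH]2)c1`. The change from compound 2 is 5-ethylpyridin-3-yl in place of phenyl on a saturated chain carbon bound to an amide-type nitrogen. In words, 5-ethylpyridin-3-yl stands in place of phenyl on a saturated chain carbon bound to an amide-type nitrogen, so that benzyl becomes (5-ethylpyridin-3-yl)methyl.

Going by the values given here, no measured step covers this change, so the expectation rests on compound 2 alone, with its limit of > 20000 nM. The expected result is a number no higher from compound 2 to compound 3 (the limit leaves the size open), with no change beyond the scatter in this assay. A further limit is the most likely report. For compound 3 the estimated value is 20000 nM, with an expected range of 10000 nM to 40000 nM.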

Compound 3, half-maximal cytotoxic concentration: > 20000 nM
Compound 3 ended at the assay's limit (the forecaster's own chance of this, stated with the estimate: 80%); the middle value lies on the limit itself.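

In this assay, for the compounds shown here, compound 2 and compound 3 both report limits of the assay and not numbers, and no step between them can be read. The compounds shown leave open whether 5-ethylpyridin-3-yl in place of phenyl changes the tolerated concentration at all, as none of the three gives a number.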